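A few compounds are considered here, and "the series" means these few. Any claim that something is new, unique, unknown or untested is made for them only; others in the source may bear on it.

Compound 1, whose structure is `CC1(C)N=C(N)N=C(N)N1c1cccc(CNC(=O)Nc2cccc(Cl)c2)c1`, was tested in an assay on isolated protein for inhibition of Dihydrofolate reductase (Mus musculus) (on this read-out lower numbers stand for lower potency and higher numbers for higher potency (the scale is a negative logarithm)), where compound 1 gives 8.05. Its companion, compound 2 with the structure `CC1(C)N=C(N)N=C(N)N1c1cccc(CCCCc2cc(Cl)ccc2S(=O)(=O)F)c1`, gives in this assay a value of 7.96. Within the data shown here, compound 1 thus stands as the higher of the two numbers known so far, but the gap to compound 2 lies within the usual scatter of repeated measurements, so the two cannot be told apart on these data.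

The next compound, compound 3 with the structure `CCN(CC)C(=O)NCc1cccc(N2C(N)=NC(N)=NC2(C)C)c1`, has not yet been measured in this assay. It differs from compound 1 in a single place:

diethylamino in place of (3-chlorophenyl)amino on a carbonyl carbon

Among the measured compounds shown here, no measured pair in this set shares that change, so its effect can only be estimated. The ring-bearing group that leaves is a sizeable part of compound 1, and the diethylamino group that enters is smaller and carries no ring. The step from compound 1 to compound 3 is expected to be a loss of about a number 0.75 log units lower from compound 1 to compound 3 (beyond the scatter), beyond the scatter. Compound 3 is therefore estimated at 7.3, within a range from 6.6 to 8.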

Compound 3, logarithm of the reciprocal of the active concentration, log(1/C): 6.11
The estimate for compound 3 lay 1.19 log units above the measured number; the whole stated range lies above it.
By their numbers in this assay, from the lowest: compound 3; then compounds 2 and 1 (each within the scatter of the next).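

In this assay, the group on this carbonyl carbon matters a great deal: putting diethylamino in place of (3-chlorophenyl)amino gives a number 1.94 log units lower from compound 1 to compound 3 (beyond the scatter) and counts as a large step. Among these compounds, the earlier compounds could not show this, since compound 1 and compound 2 differ in more than one place and offered no step to read, so this is the first direct look at what this position tolerates. The change removes the aromatic ring, the chlorine and the hydrogen-bond donor of the leaving group all together, so this single step cannot separate their contributions, and no measurement here accounts for the loss.

Still open, going by these compounds, is which part of (3-chlorophenyl)amino the potency depends on, and a plain phenylamino group would test the chlorine, while cyclohexylamino would test whether a ring needs to be aromatic. Ethylamino, which keeps the hydrogen on the nitrogen but has no ring, would show whether that hydrogen alone recovers any of what diethylamino loses.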